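Methoxy Added to a Thiosemicarbazone Aryl Ring

The compounds below may be only part of what the source reports. "The series", "measured", "known", "first", "only" and "open" are said of these compounds alone.

Measured compounds:
compound 1, `CC1=CC[C@H](C(C)(C)NC(=S)N/N=C/c2ccc(O)cc2)CC1`, in a functional assay on PC-3 cells (Homo sapiens) for inhibition, read by sulforhodamine B assay, with a stated time of 48 h (on this read-out higher numbers stand for weaker inhibition of growth and lower numbers for stronger inhibition of growth), gives 600 nM
compound 2, `COc1cc(/C=N/NC(=S)NC(C)(C)[C@H]2CC=C(C)CC2)ccc1O`, in this assay gives 300 nM
compound 3, `CC1=CC[C@H](C(C)(C)NC(=S)N/N=C(\C)c2ccccc2)CC1`, in this assay reaches only the limit > 100000 nM

Compound 1 and compound 2 share a core and differ in one place: methoxy in place of hydrogen on an aromatic carbon. That change gave a 2.0-fold lower number from compound 1 to compound 2 (0.30 log units; within the scatter), so the two values cannot be told apart.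

Compound 3 is another matter. In this assay compound 3 shows no number, only a limit, as noted in the limit of > 100000 nM in this assay, at which 1 of the 3 values shown sits. How the core of compound 3 differs from the core of compound 1 is not broken down here.

Compound 4, `COc1ccc(/C(C)=N/NC(=S)NC(C)(C)[C@H]2CC=C(C)CC2)cc1`, has not yet been measured in this assay. It stands to compound 3 as compound 2 stands to compound 1: methoxy in place of hydrogen on an aromatic carbon. This is the same kind of change as that from compound 1 to compound 2, not the same change, since the surroundings differ: in compound 2 the methoxy sits ortho to a hydroxy group and meta to a large group, whereas in compound 4 it sits para to a large group.

For the measured compounds named here, on the one measured instance of this change, which moved within the scatter, compound 4 is expected to sit close to compound 3, with an estimated step that the limit leaves unreadable from compound 3 to compound 4. For compound 4 the expected value in this assay is about 120000 nM, estimated to fall between 30000 nM and 500000 nM, and it is likely that the assay again reports only a limit.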

Compound 4, concentration for 50% growth inhibition: 83600 nM
Estimate against measurement, compound 4: 1.4-fold (0.16 log units) above; low and high end bracket the measured number.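

Carried to the core of compound 3, methoxy in place of hydrogen on an aromatic carbon, here para to a large group, gave an at least 1.1-fold lower number from compound 3 to compound 4 (0.07 log units; that floor lies within the scatter) in this assay. This shows that the change raised no sign of a different outcome on the second core, yet it does not show that the change carries over with the same size, since the step on the first core lies within the scatter and the step on the second core has only a floor, so the two instances can be neither matched nor separated: the same change on two cores in this assay, a 2.0-fold lower number (0.30 log units; within the scatter) from compound 1 to compound 2 and an at least 1.1-fold lower number (0.07 log units; that floor lies within the scatter) from compound 3 to compound 4; the limit leaves it open whether they differ Compound 3 has a limit rather than a number, so the true size of the step on its core stays unknown, and a single pair on each core supports no rule for the series: the limit of > 100000 nM in this assay, at which 1 of the 4 values shown sits.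

The compounds shown leave open whether another group on the same aromatic carbon, such as an amine or a carboxylic acid, would move the number on either core. They also leave open whether methoxy at a different place on the ring of compound 3 would give a step that can be read in full.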